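This account rests on a few compounds, and the source may have more. Where it says the series, first, only, none or still open, it means among the compounds named here.

Compound 1 `Cc1cc(Nc2ccn(Cc3cccc4ccccc34)n2)n2nc(SCc3ccc(Br)cc3)nc2n1` gives 4310 nM
Compound 2 `Cc1cc(Nc2cc(-c3ccccc3)[nH]n2)n2nc(SCC3CCCCC3)nc2n1` gives > 50000 nM
Compound 3 `Cc1cc(Nc2cc(C(C)(C)C)[nH]n2)n2nc(SCc3ccc(Br)cc3)nc2n1` gives 7290 nM

All three were tested in a functional assay on MCF7 cells (Homo sapiens) for inhibition, read by MTT assay, with a stated time of 72 h (on this read-out lower numbers stand for stronger inhibition and higher numbers for weaker inhibition), on the same read-out. Compound 2 has no actual number: its result of > 50000 nM is a limit of the assay. Compound 1 gives 4310 nM and compound 3 gives 7290 nM here, two values within the usual scatter of each other.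

Still unmeasured is compound 4 `Cc1cc(Nc2cc(-c3ccccc3)[nH]n2)n2nc(SCc3ccc(Cl)cc3)nc2n1`, which differs from compound 2 in one place: 4-chlorophenyl in place of cyclohexyl on a saturated chain carbon bound to a sulfur on a saturated chain carbon bound to a sulfur, so that cyclohexylmethyl becomes 4-chlorobenzyl. Compound 1 and compound 3 also hold a halogen-bearing aromatic ring at that place, although both differ from compound 2 elsewhere as well, so the comparison is only a loose guide.

Because compound 3 gives 7290 nM with such a ring, a large step towards lower numbers, which means stronger inhibition, is expected in this assay for this change. The expected size is an at least 5.5-fold lower number from compound 2 to compound 4 (0.74 log units; beyond the scatter) by this estimate. For compound 4 the estimated value is 9000 nM with an expected range from 2500 nM to 30000 nM on this reasoning.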

Compound 4, half-maximal inhibitory concentration: 8260 nM
The estimate for compound 4 lay 1.1-fold (0.04 log units) above the measured number, and the stated range covers the measured number.
By their numbers in this assay, from the lowest: compounds 1, 3 and 4 (each within the scatter of the next). At a limit, above all of these: compound 2.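

In this assay, putting 4-chlorophenyl in place of cyclohexyl on a saturated chain carbon bound to a sulfur gives an at least 6.0-fold lower number from compound 2 to compound 4 (0.78 log units; beyond the scatter). For the compounds shown here, this is the first pair here that differs in one place only, and it shows that this position alone can decide whether a compound gives a measurable number in this test, with the rest of the molecule held the same. Compound 2 gives > 50000 nM, which is a limit and not a number, and the size of the step rests on it: the limit of > 50000 nM in this assay, at which 1 of the 4 values shown sits.

The change swaps a non-aromatic ring for an aromatic one and adds a chlorine in a single move, and the compounds shown cannot tell which of the two matters, a question that a plain benzyl group, with no chlorine, would help to settle. Also open, going by these compounds, is how this position responds to something quite different, such as a longer chain like 2-phenylethyl, or a chain ending in an amine or a carboxylic acid.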